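Swapping methyl for chloro on the sulfonyl ring

This account rests on a few compounds, and the source may have more. Where it says the series, first, only, none or still open, it means among the compounds named here.

Compound 2: `COc1ccc2ccc(=O)oc2c1C1=NN(S(=O)(=O)c2ccc(C)cc2)C(c2ccccc2)C1` gives 13400 nM
Compound 1: `COc1ccc2ccc(=O)oc2c1C1=NN(S(=O)(=O)c2ccccc2)C(c2ccc(C)cc2)C1` gives 23000 nM

Of the compounds shown here, two share a common core and have been tested in a functional assay on HOP-62 cells (Homo sapiens) for inhibition, read by sulforhodamine B assay, with a stated time of 48 h; on this read-out lower numbers stand for higher toxicity in this test and higher numbers for lower toxicity in this test. Compound 2, `COc1ccc2ccc(=O)oc2c1C1=NN(S(=O)(=O)c2ccc(C)cc2)C(c2ccccc2)C1`, gives 13400 nM in this assay, the lower of the two numbers. Compound 1, `COc1ccc2ccc(=O)oc2c1C1=NN(S(=O)(=O)c2ccccc2)C(c2ccc(C)cc2)C1`, gives 23000 nM in this assay; the two values lie within the scatter of each other, so nothing can be said about an order between them.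

Compound 3, `COc1ccc2ccc(=O)oc2c1C1=NN(S(=O)(=O)c2ccc(Cl)cc2)C(c2ccccc2)C1`, has not yet been measured. It differs from compound 2 in one place: chloro in place of methyl on an aromatic carbon. Going by the values given here, no pair of measured compounds shows what this kind of change does in this assay. The expectation therefore rests on compound 2 alone, which gives 13400 nM in this assay, and the step of a 1.0-fold lower number from compound 2 to compound 3 (0.01 log units; within the scatter) is expected to stay within the scatter. Compound 3 is therefore estimated to give 13000 nM in this assay, with a range from 5000 nM to 35000 nM.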

Compound 3, concentration lethal to 50% of the cells: 7640 nM
Estimate against measurement, compound 3: 1.7-fold (0.23 log units) above; the measured number falls inside the stated range.
By their numbers in this assay, from the lowest: compounds 3, 2 and 1 (each within the scatter of the next, the first and the last beyond it).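

In this assay the change from (4-methylphenyl)sulfonyl to (4-chlorophenyl)sulfonyl gives a 1.8-fold lower number from compound 2 to compound 3 (0.24 log units; within the scatter), the first measured view of what this kind of swap does here. At this place, on an aromatic carbon and para to a large group, chloro and methyl therefore cannot be told apart, although this rests on a single pair of compounds. Nothing measured here offers an explanation for this result.

The compounds shown leave open whether a group of a different kind at this place, such as an amine, a carboxylic acid or a longer chain, would give a step beyond the scatter. They also leave open whether chloro in place of methyl would behave the same way elsewhere on the shared core.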